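The source may hold more compounds than are shown below. What is called first, only, known or untested is meant among the compounds shown, and "the series" means these compounds.

Measured compounds: compound 1 `CCCS(=O)(=O)Nc1cccc2c1CCC2c1ncc[nH]1`, compound 2 `Cc1c(OCC2=NCCN2)ccc(Cl)c1NS(C)(=O)=O`.

In a functional assay on CHO cells for agonist activity at Alpha-1B adrenergic receptor (Homo sapiens), read by FLIPR and calcium flux (on this read-out higher numbers stand for an effect only at larger amounts of compound and lower numbers for an effect already at smaller amounts), compound 1 gives > 10000 nM, which is a limit of the assay and not a number. In this assay compound 2 likewise gives > 10000 nM, also a limit. Going by the values given here, compound 1 thus stands at the limit of > 10000 nM in this assay, at which 2 of the 2 values shown sit; no measured step exists in this set. Compound 3 `Cn1nccc1-c1cccc2c1CCC2c1ncc[nH]1` differs from compound 1 by 1-methyl-1H-pyrazol-5-yl in place of (propylsulfonyl)amino on an aromatic carbon. With both measured values being limits, the direction of this change cannot be read from the data; a step of an at least 1.6-fold lower number from compound 1 to compound 3 (0.22 log units; that floor lies within the scatter) is expected, without any basis beyond the limits. Compound 3 is estimated at 6000 nM, in the range 1500 nM to 25000 nM.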

Compound 3, half-maximal effective concentration: > 10000 nM
Compound 3: only a limit was reported; the forecaster's own chance of this, stated with the estimate: 60%; middle value at least 1.6-fold (0.22 log units) from the limit.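

No step can be read from compound 1 to compound 3, since both values are limits of the assay: the limit of > 10000 nM in this assay, at which 3 of the 3 values shown sit.

The compounds shown leave open how (propylsulfonyl)amino and 1-methyl-1H-pyrazol-5-yl compare on the shared core in this assay.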